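Hydroxythiosemicarbazones on Vero cells: notes toward compound 4

The compounds below may be only part of what the source reports. "The series", "measured", "known", "first", "only" and "open" are said of these compounds alone.

Measured compounds in an ADME assay on Vero cells (Chlorocebus sabaeus) for cytotoxicity, read by MTT assay, with a stated time of 72 h; a higher number here means a weaker inhibitor, a lower number a stronger inhibitor:
compound 1 `Cc1ccc(/C=N/NC(=S)NO)cc1`: "not determined" (no result reported)
compound 2 `ONC(=S)N/N=C/c1ccc(Cl)cc1`: "not determined" (no result reported)
compound 3 `C/C(=N\NC(=S)NO)c1ccc(C)cc1`: > 279000 nM

Compound 1 has no number recorded in this assay, "not determined" (no result reported). For compound 2 likewise nothing is recorded, "not determined" (no result reported). Compound 3 is the only one with a result, and that result is a limit of the assay rather than a number: in this assay compound 3 gives > 279000 nM. Within the data shown here, compound 3 therefore stands at the upper edge of what has been seen here, as the sole entry with any value, and the series gives no measured step to lean on; the one fact to hand is the limit of > 279000 nM in this assay, at which 1 of the 3 values shown sits.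

Compound 4 `C/C(=N\NC(=S)NO)c1ccc([N+](=O)[O-])cc1` differs from compound 3 by a nitro in place of methyl on an aromatic carbon, (nitro in place of methyl on an aromatic carbon). Among the measured compounds shown here, with no measured step, no change beyond the usual scatter of this assay is expected from compound 3 to compound 4, and the step is estimated as an at least 1.1-fold lower number from compound 3 to compound 4 (0.04 log units; that floor lies within the scatter). Compound 4 is accordingly expected to give about 250000 nM in this assay, with a range from 60000 nM to 450000 nM, and most likely to return only a limit again, as compound 3 did with > 279000 nM.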

Compound 4, half-maximal inhibitory concentration: > 245000 nM
Compound 4 ended at the assay's limit; the forecaster's own chance of this, stated with the estimate: 65%; the middle value lies beyond the limit too.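

Compound 3 and compound 4 both rest at limits of this assay, so the nitro in place of methyl on an aromatic carbon gives no readable step. The compounds shown leave open at what concentration any of them would reach half-maximal inhibition in this assay.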